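This account rests on a few compounds, and the source may have more. Where it says the series, first, only, none or still open, it means among the compounds named here.

Compound 1 `O=C(O)CCc1ccc(NCc2ccc(C(F)(F)F)cc2)cc1` reaches 133% in a functional assay on CHO cells for agonist activity at Free fatty acid receptor 1 (Homo sapiens), read by reporter gene assay; on this read-out higher numbers stand for larger maximal responses and lower numbers for smaller maximal responses. Compound 2 `CN(C)Cc1ccc(CNc2ccc(CCC(=O)O)cc2)cc1`, which carries (dimethylamino)methyl in place of trifluoromethyl on an aromatic carbon, reaches 12% in this assay, and the change is a number 121 percentage points lower from compound 1 to compound 2 (beyond the scatter). Within the data shown here, of the two numbers known so far, compound 2 therefore stands lowest, its only neighbour being compound 1 at the higher figure.

Compound 3 `O=C(O)CCc1ccc(NCc2ccc(O)cc2)cc1` is not yet measured. It differs from compound 2 by hydroxy in place of (dimethylamino)methyl on an aromatic carbon. Among the measured compounds shown here, only one measured step bears on this change: the step from compound 1 to compound 2, which introduced the (dimethylamino)methyl group that now leaves, was large, a number 121 percentage points lower from compound 1 to compound 2 (beyond the scatter). For the measured compounds named here, no measured pair shows what hydroxy does at this place, so the size of the recovery is open. Compound 3 is expected to rise well beyond the scatter, by a number 58 percentage points higher from compound 2 to compound 3 (beyond the scatter). Compound 3 is estimated to reach 70% in this assay, with a plausible range from 25% to 125%.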

Compound 3, largest response reached (reported as percent of maximum), in percent of the reference or control that the assay uses: 37%
Compound 3: the middle estimate sits 33 percentage points above what was measured; the measured number falls inside the stated range.
By their numbers in this assay, from the lowest: compound 2; then compound 3; then compound 1.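

With hydroxy at this place, on an aromatic carbon para to a large group, the maximal response in this assay shows a number 25 percentage points higher from compound 2 to compound 3 (beyond the scatter), so the two groups that replace trifluoromethyl here are distinguishable, although the gain is modest. Hydroxy still recovers only a small part of the earlier loss, with a number 96 percentage points lower from compound 1 to compound 3 (beyond the scatter), which means the large fall from trifluoromethyl is not confined to (dimethylamino)methyl; among these three compounds, both replacements remain far below compound 1. The information available offers no explanation for this order among the three groups.

The compounds shown leave open whether a methoxy group, a chlorine atom or a nitrile at this place would stay close to compound 1 or fall towards compound 3, and therefore how much of the high response is specific to trifluoromethyl. Among these compounds, it also remains open how a simple primary amine would compare with hydroxy and (dimethylamino)methyl at this place, and whether the same order of groups would hold on any core other than the one shared by these compounds.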